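The source may hold more compounds than are shown below. What is called first, only, known or untested is meant among the compounds shown, and "the series" means these compounds.

Compound 1 `CNC(=O)C#Cc1ccc(NC(=O)Nc2ccc(Cl)c(C(F)(F)F)c2)cc1` in a functional assay on HT-29 cells (Homo sapiens) for inhibition, read by MTT assay, with a stated time of 120 h (on this read-out higher numbers stand for weaker inhibition and lower numbers for stronger inhibition), gives 14000 nM, the highest of the two numbers in the series. Compound 2 `CC(NC(=O)C#Cc1ccc(NC(=O)Nc2ccc(Cl)c(C(F)(F)F)c2)cc1)c1ccccc1` gives 4920 nM in this assay; the step of a 2.8-fold lower number from compound 1 to compound 2 (0.45 log units; beyond the scatter) is the only measured one. Compound 3 `CC(NC(=O)/C=C/Oc1ccc(NC(=O)Nc2ccc(Cl)c(C(F)(F)F)c2)cc1)c1ccccc1` returns only the limit > 50000 nM in this assay. Compound 4 `CNC(=O)c1cccc(-c2ccc(NC(=O)Nc3ccc(Cl)c(C(F)(F)F)c3)cc2)c1` differs from compound 1 by 3-(methylcarbamoyl)phenyl in place of 2-(methylcarbamoyl)ethynyl on an aromatic carbon. For the measured compounds named here, no measured step touches this part of the core; the step from compound 1 to compound 2 concerns the amide-type nitrogen and does not bear on it. Compound 3 shows that another altered link gave only a limit. The expected step of a 1.4-fold lower number from compound 1 to compound 4 (0.15 log units; within the scatter) is therefore small and uncertain, with no direction beyond the scatter claimed. Compound 4 is estimated at 10000 nM, with a range of 2500 nM to 40000 nM.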

Compound 4, half-maximal inhibitory concentration: 29300 nM
Beside the measured number, compound 4's estimate is 2.9-fold (0.47 log units) below it; the range from low to high includes it.
By their numbers in this assay, from the lowest: compound 2; then compound 1; then compound 4. At a limit, above all of these: compound 3.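

In this assay, for the compounds shown here, the first measured change at this aromatic carbon, 3-(methylcarbamoyl)phenyl in place of 2-(methylcarbamoyl)ethynyl, gives a 2.1-fold higher number from compound 1 to compound 4 (0.32 log units; beyond the scatter). The ethynyl link is therefore not essential for a measurable reading, although inhibition is modestly weaker with the aromatic ring in its place. Compound 4 still gives a number, whereas compound 3 is the compound at a limit: the limit of > 50000 nM in this assay, at which 1 of the 4 values shown sits.

Open, going by these compounds, is whether 1-phenylethyl in place of methyl on the amide-type nitrogen of compound 4 would also lower the number. Also open, on these data alone, is how a carboxylic acid or an amine would read in place of the methylcarbamoyl group.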